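The compounds below may be only part of what the source reports. "The series", "measured", "known", "first", "only" and "open" are said of these compounds alone.

Measured in a functional assay on DU-145 cells (Homo sapiens) for inhibition, read by trypan blue exclusion, with a stated time of 96 h; a higher number here means a weaker inhibitor of growth, a lower number a stronger inhibitor of growth:
Compound 1 `O=C(/C(=C\c1ccc(Br)cc1)SCc1ccc(Cl)cc1)c1ccc(Cl)cc1`: 1000 nM
Compound 2 `O=C(/C(=C\c1ccc(Cl)cc1)SCc1ccc(F)cc1)c1ccc(Cl)cc1`: 10000 nM

Compound 2 stands highest of the two at 10000 nM, and its gap to compound 1 lies beyond the scatter. Compound 3 `O=C(/C(=C\c1ccc(Br)cc1)SCc1ccc(F)cc1)c1ccc(Cl)cc1` is compound 2 with one change, bromo in place of chloro on an aromatic carbon. For the measured compounds named here, compound 1 and compound 2 differ in more than one place, so this assay offers no measured step for this change alone. Compound 1, at 1000 nM, also carries the 4-bromophenyl group, which gives only a weak hint toward a lower number. A modest move toward stronger growth inhibition is therefore expected, expressed as the estimated 3.3-fold lower number from compound 2 to compound 3 (0.52 log units; beyond the scatter). For compound 3 the expected value is 3000 nM, with an estimated range of 800 nM to 10000 nM.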

Compound 3, concentration for 50% growth inhibition: 9000 nM
Compound 3: the middle estimate sits 3.0-fold (0.48 log units) below what was measured; the measured number falls inside the stated range.
By their numbers in this assay, from the lowest: compound 1; then compounds 3 and 2 (each within the scatter of the next).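

In this assay, the exchange of 4-chlorophenyl for 4-bromophenyl gives a 1.1-fold lower number from compound 2 to compound 3 (0.05 log units; within the scatter), so with a fluoro on the other halogenated benzyl group this position does not separate bromo from chloro. The exchange of fluoro for chloro on an aromatic carbon gives a 9.0-fold higher number from compound 1 to compound 3 (0.95 log units; beyond the scatter), which ties the lower number of compound 1 to its chloro on that benzyl group and not to its 4-bromophenyl group. No measurement shown offers an explanation for either step.

As far as these compounds go, whether bromo and chloro also stay level when that benzyl group carries chloro instead of fluoro remains open. So does the outcome of putting a methoxy group, an amine or a carboxylic acid in place of the halogen at either position.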